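Butyl on the piperazine nitrogen of compound 3

The source may hold more compounds than are shown below. What is called first, only, known or untested is meant among the compounds shown, and "the series" means these compounds.

Measured so far:
- compound 1 `O=C1c2c[n+]([O-])c3ccccc3c2C(=O)c2c1c1ccccc1n2Cc1cn(CC(O)CO)nn1`: 250 nM
- compound 2 `O=C1c2c[n+]([O-])c3ccccc3c2C(=O)c2c1c1ccccc1n2CCCCN1CCCCC1`: 200 nM
- compound 3 `O=C1c2c[n+]([O-])c3ccccc3c2C(=O)c2c1c1ccccc1n2CCCCN1CCNCC1`: 700 nM

In a functional assay on HCT-116 cells (Homo sapiens) for cytotoxicity, read by MTT assay, with a stated time of 72 h (on this read-out lower numbers stand for stronger inhibition and higher numbers for weaker inhibition), compound 3 gives the highest number of the three. The step of a 2.8-fold higher number from compound 1 to compound 3 (0.45 log units; beyond the scatter) and the step of a 3.5-fold higher number from compound 2 to compound 3 (0.54 log units; beyond the scatter) both lie beyond the scatter, whereas a 1.3-fold lower number from compound 1 to compound 2 (0.10 log units; within the scatter) does not, so compound 1 and compound 2 cannot be ordered against each other on this assay.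

Compound 4 `CCCCN1CCN(CCCCn2c3c(c4ccccc42)C(=O)c2c[n+]([O-])c4ccccc4c2C3=O)CC1` differs from compound 3 by butyl in place of hydrogen on an amine nitrogen in a ring. The step that bears most directly on this change is a 3.5-fold higher number from compound 2 to compound 3 (0.54 log units; beyond the scatter), where the ring attached four bonds along the chain from the aromatic nitrogen changed from piperidin-1-yl to piperazin-1-yl. Compound 4 carries 4-butylpiperazin-1-yl at that position, a ring that, like piperidin-1-yl in compound 2, bears no hydrogen on its chain-side nitrogen. Compound 2 gives 200 nM and compound 3 gives 700 nM in this assay; the expectation is therefore that compound 4 moves back toward the number of compound 2, with a step of roughly a 2.0-fold lower number from compound 3 to compound 4 (0.30 log units; within the scatter), a lower number of modest size. The estimate for compound 4 in this assay is 350 nM, with a range from 150 nM to 800 nM.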

Compound 4, half-maximal inhibitory concentration: 1920 nM
Compound 4: the middle estimate sits 5.5-fold (0.74 log units) below what was measured; the measured number lies above the stated range.
By their numbers in this assay, from the lowest: compounds 2 and 1 (each within the scatter of the next); then compound 3; then compound 4.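

In this assay, replacing the hydrogen on the ring amine nitrogen with butyl gives a 2.7-fold higher number from compound 3 to compound 4 (0.44 log units; beyond the scatter) and does not return the series toward the piperidin-1-yl compound. The change from compound 2 thus grows from a 3.5-fold higher number from compound 2 to compound 3 (0.54 log units; beyond the scatter) for piperazin-1-yl to a 9.6-fold higher number from compound 2 to compound 4 (0.98 log units; beyond the scatter) for 4-butylpiperazin-1-yl, so removing the hydrogen from that nitrogen is not enough to recover the number of compound 2, and the group that replaces it matters at this position. Within these compounds, the ring at the end of the chain affects the cytotoxicity read-out through both its second nitrogen and what that nitrogen carries, but nothing available explains the shift.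

Still open, on these data alone, is whether methyl or ethyl on the same nitrogen would give a number near compound 3 or compound 4, which would show whether the rise tracks the length of the alkyl chain or is specific to butyl. Also open, as far as these compounds go, is how an acetyl or a 2-hydroxyethyl group at that nitrogen would read in this assay against the butyl of compound 4.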